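The source may hold more compounds than are shown below. What is called first, only, known or untested is meant among the compounds shown, and "the series" means these compounds.

Measured in a functional assay on MCF7 cells (Homo sapiens) for cytotoxicity, read by CCK-8 assay, with a stated time of 72 h; on this read-out higher numbers stand for weaker inhibition and lower numbers for stronger inhibition:
- compound 1 `C=CCn1c(=O)/c(=C\c2ccccc2Cl)[nH]c(=O)/c1=C\c1ccccc1OC`: 4700 nM
- compound 2 `C=CCn1c(=O)/c(=C\c2cccc(Cl)c2Cl)[nH]c(=O)/c1=C\c1ccccc1OC`: 2100 nM
- compound 3 `C=CCn1c(=O)/c(=C\c2cccc(Br)c2)[nH]c(=O)/c1=C\c1ccccc1OC`: 5400 nM

Compound 1 sits second highest of the three numbers; its nearest neighbour is compound 3, a 1.1-fold higher number from compound 1 to compound 3 (0.06 log units; within the scatter), and its furthest is compound 2, a 2.2-fold lower number from compound 1 to compound 2 (0.35 log units; beyond the scatter). Compound 4 `C=CCn1c(=O)/c(=C\c2ccc(C)cc2)[nH]c(=O)/c1=C\c1ccccc1OC` differs from compound 1 by 4-methylphenyl in place of 2-chlorophenyl on a double-bonded chain carbon bound to an aromatic carbon. Among the measured compounds shown here, the step that bears on this change is the aryl swap from compound 1 to compound 3, which stayed within the scatter; the only modest steps, a 2.2-fold lower number from compound 1 to compound 2 (0.35 log units; beyond the scatter) and a 2.6-fold higher number from compound 2 to compound 3 (0.41 log units; beyond the scatter), involve the dichloro pattern that compound 4 does not carry. On this basis no step beyond the scatter in this assay is expected, in either direction. Compound 4 is therefore estimated at 5000 nM, within 2000 nM to 12000 nM, meaning a 1.1-fold higher number from compound 1 to compound 4 (0.03 log units; within the scatter).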

Compound 4, half-maximal inhibitory concentration: "not active" (no number reported)
The entry for compound 4 holds no number; the estimate stays without a comparison.
By their numbers in this assay, from the lowest: compound 2; then compounds 1 and 3 (each within the scatter of the next).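

Among the compounds shown here, compound 4 is entered as "not active" with no number, so no step linking it to compound 1, compound 2 or compound 3 can be read. Nothing shown explains this result. The compounds shown leave open where compound 4 stands numerically against compound 1.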